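From 4-ethoxyphenyl to benzyl on the amine nitrogen

The compounds below may be only part of what the source reports. "The series", "measured", "known", "first", "only" and "open" are said of these compounds alone.

- compound 1 `Cc1ccc(NC2=CC(=O)c3c(nc4n3[C@H]3OC[C@@H](O)[C@H]3OC4)C2=O)cc1` gives 1550 nM
- compound 2 `CCOc1ccc(NC2=CC(=O)c3c(nc4n3[C@H]3OC[C@@H](O)[C@H]3OC4)C2=O)cc1` gives 2090 nM

In a functional assay on MGC-803 cells (Homo sapiens) for inhibition, read by sulforhodamine B assay (on this read-out higher numbers stand for weaker inhibition and lower numbers for stronger inhibition), compound 2 at 2090 nM cannot be told apart from compound 1 at 1550 nM. Among the compounds with values here, the one measured step, a 1.3-fold higher number from compound 1 to compound 2 (0.13 log units; within the scatter), puts ethoxy in place of methyl on an aromatic carbon. Compound 3 `O=C1C(NCc2ccccc2)=CC(=O)c2c1nc1n2[C@H]2OC[C@@H](O)[C@H]2OC1` differs from compound 2 by a larger swap: benzyl in place of 4-ethoxyphenyl on an amine nitrogen. The measured step altered only a group on an aromatic carbon, so it bears on this swap only loosely and gives no direction. No shift beyond the scatter is therefore expected in this assay, though with wide uncertainty. The estimated change is a 1.2-fold higher number from compound 2 to compound 3 (0.08 log units; within the scatter). Compound 3 is expected at about 2500 nM, within an estimated range of 800 nM to 8000 nM.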

Compound 3, half-maximal inhibitory concentration: 3490 nM
For compound 3 the middle estimate is 1.4-fold (0.14 log units) below the measured one; measured number inside the range.
By their numbers in this assay, from the lowest: compounds 1, 2 and 3 (each within the scatter of the next, the first and the last beyond it).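

In this assay, benzyl in place of 4-ethoxyphenyl on the amine nitrogen gives a 1.7-fold higher number from compound 2 to compound 3 (0.22 log units; within the scatter) and so cannot be told apart from no change, which shows that this nitrogen accepts a benzyl group as well as a substituted phenyl ring. Benzyl in place of 4-methylphenyl gives a 2.3-fold higher number from compound 1 to compound 3 (0.35 log units; beyond the scatter) and is the first step in this set to pass the scatter, though only modestly, so the choice of group here can matter a little. No supporting evidence is available to explain this small difference.

On these data alone, it remains open whether a benzyl group carrying methyl or ethoxy on its ring would behave like compound 3 or like compound 1. As far as these compounds go, how a longer chain such as phenethyl, or a saturated ring such as cyclohexyl, would fare on this nitrogen also stays unknown.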